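Dog Exposure After Changing One Aromatic Group

This account rests on a few compounds, and the source may have more. Where it says the series, first, only, none or still open, it means among the compounds named here.

compound 1, `CC[C@H](C)[C@@H]1C(=O)N[C@H](C2Cc3ccccc3C2)C(=O)N1[C@@H](C(=O)N(C)C)c1ccc(C)[n+]([O-])c1`: 73 ng.h/mL
compound 2, `CC[C@@H](C)[C@@H]1C(=O)N[C@H](C2Cc3ccccc3C2)C(=O)N1[C@@H](C(=O)N1CCOCC1)c1ccc(C)nc1`: 138 ng.h/mL

In an ADME assay on the whole organism (plasma) for pharmacokinetics, with Canis familiaris (Canis lupus familiaris) as the target, at a dose of 0.6 mg/kg by the oral route (a lower number here means less compound in the circulation, a higher number more compound in the circulation at the dose given), compound 1 gives 73 ng.h/mL, the lower of the two figures, though the gap to compound 2, which gives 138 ng.h/mL, is within the scatter, so no real difference is shown. Compound 3, `CC[C@H](C)[C@@H]1C(=O)N[C@H](C2Cc3ccccc3C2)C(=O)N1[C@@H](C(=O)N(C)C)c1cnc(C)cc1C`, comes from compound 1 by a group of 8 heavy atoms (7 carbon, 1 nitrogen; one six-membered aromatic ring with 1 hetero atom) in place of a group of 8 heavy atoms (6 carbon, 1 nitrogen, 1 oxygen; one six-membered aromatic ring with 1 hetero atom), on a saturated chain carbon bound to an amide-type nitrogen in a ring and a carbonyl carbon. Within the data shown here, no measured pair shows what this change does to exposure. The step of a 1.5-fold higher number from compound 1 to compound 3 (0.18 log units; within the scatter) is expected to be a small rise, not clearly beyond the scatter. Compound 3 is estimated to give 110 ng.h/mL, with a range from 40 ng.h/mL to 300 ng.h/mL.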

Compound 3, area under the concentration-time curve: 140 ng.h/mL
Compound 3: middle estimate off by 1.3-fold (0.10 log units), on the low side; measured number inside the range.
By their numbers in this assay, from the lowest: compounds 1, 2 and 3 (each within the scatter of the next).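

In this assay, on the saturated chain carbon bound to an amide-type nitrogen in a ring and a carbonyl carbon, replacing the oxygen-bearing aromatic group of compound 1 with 4,6-dimethylpyridin-3-yl gives a 1.9-fold higher number from compound 1 to compound 3 (0.28 log units; within the scatter). This change therefore shows no real difference in exposure. Nothing available explains this result.

Going by these compounds, it remains open whether a plain phenyl group or a pyridine ring carrying a carboxylic acid at this place would shift exposure beyond the scatter.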